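Chloro in Place of Trifluoromethyl for Compound 3

A few compounds are considered here, and "the series" means these few. Any claim that something is new, unique, unknown or untested is made for them only; others in the source may bear on it.

Compound 2 `CC(C(=O)N1CCN(c2cccc(C(F)(F)F)c2)CC1)N1C(=O)CCC1=O` gives 100% in a functional assay on the whole organism (strain Swiss) with Mus musculus as the target, with a stated time of 1 h, at a dose of 300 mg/kg (on this read-out higher numbers stand for a stronger effect at the one dose given and lower numbers for a weaker effect), the highest of the two numbers shown. Compound 1 `COCC(C(=O)N1CCN(c2cccc(C(F)(F)F)c2)CC1)N1C(=O)CCC1=O` gives 75% in this assay, with a number 25 percentage points higher from compound 1 to compound 2 (beyond the scatter). Compound 3 `CC(C(=O)N1CCN(c2cccc(Cl)c2)CC1)N1C(=O)CCC1=O` differs from compound 2 by chloro in place of trifluoromethyl on an aromatic carbon. Going by the values given here, the one measured step concerns a saturated chain carbon and does not bear on an aromatic substituent, so no direct guide exists for this change. Since compound 2 stands at the top of the scale, compound 3 is expected to give 90% (range 70% to 100%). This expectation means a number 10 percentage points lower from compound 2 to compound 3 (within the scatter), a step anticipated to lie within the scatter.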

Compound 3, a percentage reported as activity, at one dose (the size of the read-out at that dose, not a potency): 75%
The estimate for compound 3 lay 15 percentage points above the measured number; measured number inside the range.
By their numbers in this assay, from the lowest: compounds 1 and 3 (each within the scatter of the next); then compound 2.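

The earlier step concerned only a saturated chain carbon; here, in this assay, the substituent on an aromatic carbon also moves the read-out, with a number 25 percentage points lower from compound 2 to compound 3 (beyond the scatter). At this position on the shared core, chloro therefore does not match trifluoromethyl at the one dose given. Nothing shown accounts for this difference.

The compounds shown leave open how a nitrile, a methoxy group or plain hydrogen would read on the same aromatic carbon. They also leave open whether chloro would give the same step with the methoxy-bearing chain of compound 1.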